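This account rests on a few compounds, and the source may have more. Where it says the series, first, only, none or still open, it means among the compounds named here.

Working notes on the series.

Of the compounds shown here, two carry numbers so far. Compound 1 `O=C(O)c1ccc(-c2cnc(C(=O)CCCCCCc3ccccc3)o2)cc1` gives 60 nM in an assay (Rattus norvegicus) for inhibition of Fatty-acid amide hydrolase 1 (Homo sapiens); a lower number here means a stronger inhibitor, a higher number a weaker inhibitor. Compound 2 `NS(=O)(=O)c1ccc(-c2cnc(C(=O)CCCCCCc3ccccc3)o2)s1` gives 3 nM in this assay. The single measured step between them, a 20-fold lower number from compound 1 to compound 2 (1.30 log units; beyond the scatter), concerns the aryl group on the shared core, and it places compound 2 at the low end of the two numbers shown, with compound 1 the only neighbour and a far weaker one.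

Compound 3 `O=C(CCCCCCc1ccccc1)c1ncc(C(=O)C(F)(F)F)o1` is the next member. Its change from compound 2 is (trifluoromethyl)carbonyl in place of 5-sulfamoylthiophen-2-yl on an aromatic carbon, on the ring atom described as next to the ring oxygen and two ring bonds from the ring atom that bears a large group.

Going by the values given here, no measured step covers a swap of this kind: the only step known, a 20-fold lower number from compound 1 to compound 2 (1.30 log units; beyond the scatter), exchanges one aromatic substituent for another at the same place and shows that substituent changes there move the number strongly. A change of comparable or larger magnitude is therefore plausible, but its direction is not fixed by the data; with no aromatic group left at that position, a weakening is taken as the more likely outcome. Compound 3 is estimated at 30 nM in this assay, within 3 nM to 300 nM, an expected step of a 10-fold higher number from compound 2 to compound 3 (1.00 log units; beyond the scatter).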

Compound 3, inhibition constant: 4 nM
Estimate against measurement, compound 3: 7.5-fold (0.88 log units) above, within the range that was stated.
By their numbers in this assay, from the lowest: compounds 2 and 3 (each within the scatter of the next); then compound 1.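

In this assay, the step of a 1.3-fold higher number from compound 2 to compound 3 (0.12 log units; within the scatter) lies within the scatter, so at this place, next to the ring oxygen, the (trifluoromethyl)carbonyl, with no ring and 6 heavy atoms, cannot be told apart from the 5-sulfamoylthiophen-2-yl, with its five-membered aromatic ring and 9 heavy atoms. The step of a 15-fold lower number from compound 1 to compound 3 (1.18 log units; beyond the scatter) lies beyond the scatter and is close in size to the earlier step from the same starting compound, so among the three groups shown it is the 4-carboxyphenyl that stands apart, and an aromatic ring at this place is not needed for a number in the low range seen here. The data shown hold nothing that explains why two groups so unlike in their counts give indistinguishable numbers.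

Still open, from the compounds shown here alone, is whether this tolerance extends to other small groups at the same place, such as a nitrile, a methyl ester or a plain acetyl carrying no fluorine. Going by these compounds, it is also open whether compound 3 and compound 2 would stay indistinguishable with a shorter chain in place of the phenylhexyl carbonyl side of the shared core.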